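This account rests on a few compounds, and the source may have more. Where it says the series, first, only, none or still open, it means among the compounds named here.

Three related amides were examined for cytotoxicity in an ADME assay on HEL cells (Homo sapiens) for cytotoxicity, read by microscopy, with a stated time of 6 days; on this read-out lower numbers stand for higher toxicity in this test and higher numbers for lower toxicity in this test. Compound 1 `CCCCCCCCNc1nccnc1C(=O)NCc1ccccc1` carries an octyl chain on the amine attached to its core, and compound 2 `CCCCNc1nccnc1C(=O)NCc1ccccc1` carries a butyl chain on the same core. Compound 3 `CCCCNc1cncc(C(=O)NCc2ccccc2)n1` carries the butyl chain on a different core; the difference between the two cores is not broken down here. Compound 4 `CCCCCCCCNc1cncc(C(=O)NCc2ccccc2)n1` is the octyl counterpart of compound 3 and has not yet been measured.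

In this assay compound 1 gives a limit of the assay, > 100000 nM. In this assay compound 2 likewise gives a limit of the assay, > 100000 nM. In this assay compound 3 also gives a limit of the assay, > 100000 nM. The change from compound 2 to compound 1 is butyl in place of hydrogen on a saturated chain carbon, four bonds along the chain from a nitrogen on an aromatic ring, and a step that the two limits leave unreadable from compound 2 to compound 1, since both values sit at the limit. The change from compound 3 to compound 4 is butyl in place of hydrogen on a saturated chain carbon, four bonds along the chain from a nitrogen on an aromatic ring, the same change carried out on the other core.

The expected step to compound 4 is a step that the limit leaves unreadable from compound 3 to compound 4, which is an estimate. This expectation rests on compound 1, whose value > 100000 nM remains a limit after the same change, and on (the limit of > 100000 nM in this assay, at which 3 of the 3 values shown sit). Compound 4 is therefore expected to give 150000 nM, within a range from 100000 nM to 300000 nM.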

Compound 4, minimum cytotoxic concentration: > 100000 nM
Compound 4: no number, only a limit; the forecaster's own chance of this, stated with the estimate: 85%; the middle value lies beyond the limit too.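

Going by these compounds alone, compound 3 and compound 4 both give only a limit of the assay, so the step between them cannot be read and this result yields no new step. The compounds shown leave open at what concentration, if any, toxicity would appear in this assay, and whether the chain or the core alters it, as every value shown is a limit: the limit of > 100000 nM in this assay, at which 4 of the 4 values shown sit.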